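The source may report more compounds than this note shows. Statements on the series, on what has been measured and on what is new or still open speak of the compounds shown alone.

Of the compounds shown here, three built on a shared core have been measured in an ADME assay on HEK-293T cells (Homo sapiens) for antiproliferative activity, read by MTT assay, with a stated time of 48 h, in the presence of a further agent that is not named here; on this read-out lower numbers stand for higher toxicity in this test and higher numbers for lower toxicity in this test. Compound 1 `Cc1ccc(-c2nn(-c3ccccc3)cc2C(=O)NOCc2ccccc2)cc1` gives 40800 nM. Compound 2 `Cc1ccc(-c2nn(-c3ccccc3)cc2C(=O)NOCc2ccccc2F)cc1` carries fluoro in place of hydrogen on an aromatic carbon and gives 20600 nM; the step of a 2.0-fold lower number from compound 1 to compound 2 (0.30 log units; within the scatter). Compound 3 `O=C(NOCc1ccccc1)c1cn(-c2ccccc2)nc1-c1ccc(Cl)cc1` differs from compound 1 by chloro in place of methyl on an aromatic carbon, the step being a 1.3-fold higher number from compound 1 to compound 3 (0.10 log units; within the scatter). In this assay compound 3 gives 51900 nM. Compound 3 and compound 2 are separated by a gap beyond the scatter, while compound 3 and compound 1 lie within it.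

Compound 4 `O=C(NOCc1ccccc1F)c1cn(-c2ccccc2)nc1-c1ccc(Cl)cc1` is not yet measured. It carries fluoro in place of hydrogen on an aromatic carbon, the same change that turns compound 1 into compound 2, at the same place on the ring. Among the measured compounds shown here, compound 4 is expected to show a step of a 1.9-fold lower number from compound 3 to compound 4 (0.27 log units; within the scatter) in this assay, resting on the single earlier example, because the step of a 2.0-fold lower number from compound 1 to compound 2 (0.30 log units; within the scatter) is the only guide available and it lay within the scatter. Compound 4 is therefore estimated at 28000 nM, with a range from 14000 nM to 60000 nM.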

Compound 4, half-maximal cytotoxic concentration: 126000 nM
Compound 4: middle estimate off by 4.5-fold (0.65 log units), on the low side; the whole stated range lies below it.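

In this assay, the change from benzyl to 2-fluorobenzyl gives a 2.4-fold higher number from compound 3 to compound 4 (0.39 log units; beyond the scatter), and this does not repeat what the same change did on the core of compound 1: the same change on two cores in this assay, a 2.0-fold lower number (0.30 log units; within the scatter) from compound 1 to compound 2 and a 2.4-fold higher number (0.39 log units; beyond the scatter) from compound 3 to compound 4, 4.8-fold (0.68 log units) apart, beyond the scatter of two such steps

Read the other way round, chloro in place of methyl gives a 6.1-fold higher number from compound 2 to compound 4 (0.79 log units; beyond the scatter) when the 2-fluorobenzyl group is present, which does not match the step seen with the plain benzyl group: the same change on two cores in this assay, a 1.3-fold higher number (0.10 log units; within the scatter) from compound 1 to compound 3 and a 6.1-fold higher number (0.79 log units; beyond the scatter) from compound 2 to compound 4, 4.8-fold (0.68 log units) apart, beyond the scatter of two such steps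

This shows that neither change can simply be carried from one core to another among these four compounds, but the two gaps come from the same four compounds and rest on the single value of compound 4, so they count as one observation and do not show why the steps differ.

On these data alone, whether the same holds with chloro, methoxy or a nitrile in place of the fluoro remains open. So does whether a bromo or a methoxy in place of the chloro or methyl would behave in the same way.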